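Cyano for Methyl on Selenium: Projecting Compound 4

The source may hold more compounds than are shown below. What is called first, only, known or untested is meant among the compounds shown, and "the series" means these compounds.

Of the compounds shown here, three have been measured so far. Compound 1 `C[Se]c1ccc(N(C)c2nc(C3CC3)nc3ccccc23)cc1` gives 15 nM in a functional assay on HCT-116 cells (Homo sapiens) for inhibition, read by MTT assay, with a stated time of 48 h; on this read-out lower numbers stand for stronger inhibition and higher numbers for weaker inhibition. Compound 3 `C[Se]c1ccc(N(C)c2nc(C)nc3ccccc23)cc1Cl` gives 5 nM in this assay, and compound 2 `Cc1nc(N(C)c2ccc([Se]C#N)c(Cl)c2)c2ccccc2n1` gives 12 nM. Compound 1 and compound 3 differ in more than one place, and the difference between the two cores is not broken down here; their values sit apart, with compound 1 the higher of the two. Compound 2 differs from compound 3 by a single change, (cyano in place of methyl on a selenium), and this change gave a 2.4-fold higher number from compound 3 to compound 2 (0.38 log units; beyond the scatter).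

Compound 4 `CN(c1ccc([Se]C#N)cc1)c1nc(C2CC2)nc2ccccc12` is not yet measured. Going by the values given here, it differs from compound 1 by cyano in place of methyl on a selenium, which is the same change in the same place as the one that separates compound 3 and compound 2. Among the compounds with values here, a step of comparable size is therefore expected from compound 1 to compound 4, namely a 2.4-fold higher number from compound 1 to compound 4 (0.38 log units; beyond the scatter), and this expectation rests on the single earlier instance, a 2.4-fold higher number from compound 3 to compound 2 (0.38 log units; beyond the scatter). Compound 4 is accordingly expected to give about 36 nM in this assay, with a plausible span from 15 nM to 90 nM.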

Compound 4, half-maximal inhibitory concentration: 62 nM
Compound 4: middle estimate off by 1.7-fold (0.24 log units), on the low side; the range from low to high includes it.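

On the core of compound 1, cyano in place of methyl on a selenium gave a 4.1-fold higher number from compound 1 to compound 4 (0.62 log units; beyond the scatter) in this assay. Set beside the earlier case on the other core, the change raised the number both times, and the two steps cannot be told apart in size: the same change on two cores in this assay, a 2.4-fold higher number (0.38 log units; beyond the scatter) from compound 3 to compound 2 and a 4.1-fold higher number (0.62 log units; beyond the scatter) from compound 1 to compound 4, 1.7-fold (0.24 log units) apart, within the scatter of two such steps. This shows that the change carried over from one core to the other in direction and, within the scatter, in size, but it does not show that the core alters the size of the step, it gives no reason for the rise, and two cores do not establish a rule for the whole series.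

The compounds shown leave open how another group on the selenium, such as an ethyl or a benzyl, would read in this assay. Also open, going by these compounds, is whether the same step would appear with sulfur in place of the selenium, or on a core carrying an amine.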